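The compounds below may be only part of what the source reports. "The series", "measured", "known", "first", "only" and "open" are said of these compounds alone.

Measured compounds:
- compound 1, `CCN(CC)S(=O)(=O)c1ccc(S(=O)(=O)N2CCC[C@@H](C(=O)N(C)C(C)C)C2)cc1`: in a functional assay on MIA PaCa-2 cells (Homo sapiens) for inhibition, read by MTT assay, with a stated time of 3 days (a higher number here means a weaker inhibitor, a lower number a stronger inhibitor), compound 1 gives > 10000 nM, a limit of the assay
- compound 2, `CCN1CC(NC(=O)[C@@H]2CCCN(S(=O)(=O)c3ccc(S(=O)(=O)N(CC)CC)cc3)C2)C1`: in this assay compound 2 gives > 10000 nM, a limit of the assay
- compound 3, `CCN(CC)S(=O)(=O)c1ccc(S(=O)(=O)N2CCC[C@@H](C(=O)NC3CN(C(=O)OC(C)(C)C)C3)C2)cc1`: in this assay compound 3 gives > 10000 nM, a limit of the assay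

Compound 3 therefore stands nowhere on a scale; its value is a limit only, as are both others shown (the limit of > 10000 nM in this assay, at which 3 of the 3 values shown sit). The steps a step that the two limits leave unreadable from compound 1 to compound 3 and a step that the two limits leave unreadable from compound 2 to compound 3, and likewise a step that the two limits leave unreadable from compound 1 to compound 2, run from one limit to another and their size cannot be read.

The next compound, compound 4, `CCN(CC)S(=O)(=O)c1ccc(S(=O)(=O)N2CCC[C@@H](C(=O)NC3CN(C(=O)NC(C)(C)C)C3)C2)cc1`, differs from compound 3 by (tert-butyl)amino in place of tert-butoxy on a carbonyl carbon; the same change read one bond further out is tert-butoxycarbonyl to (tert-butyl)carbamoyl on the azetidine nitrogen.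

Going by the values given here, no measured step gives a direction for this exchange. Every variation at the amide side so far has stayed at the limit (the limit of > 10000 nM in this assay, at which 3 of the 3 values shown sit), so the expectation for compound 4 is again a limit rather than a number. The expected step that the limit leaves unreadable from compound 3 to compound 4 is accordingly not resolvable. Compound 4 is estimated at 15000 nM, within 7000 nM to 50000 nM.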

Compound 4, half-maximal inhibitory concentration: > 10000 nM
Compound 4 was reported as a limit; the forecaster's own chance of this, stated with the estimate: 85%; the middle value is on the limit's open side.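

No step between compound 1, compound 2, compound 3 and compound 4 can be read in this assay, since each value is a limit of the assay: the limit of > 10000 nM in this assay, at which 4 of the 4 values shown sit.

The compounds shown leave open whether any change to the shared core gives a readable value in this assay.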